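Amide swap on a disulfonyl piperidine core: compound 3

A few compounds are considered here, and "the series" means these few. Any claim that something is new, unique, unknown or untested is made for them only; others in the source may bear on it.

Measured compounds:
compound 1 `CCN(CC)S(=O)(=O)c1ccc(S(=O)(=O)N2CCC[C@@H](C(=O)N3CCC(O)CC3)C2)cc1`, 870 nM
compound 2 `CCN(CC)S(=O)(=O)c1ccc(S(=O)(=O)N2CCC[C@@H](C(=O)N[C@@H]3CCOC3)C2)cc1`, 750 nM

In a functional assay on MIA PaCa-2 cells (Homo sapiens) for inhibition, read by MTT assay, with a stated time of 7 days (a higher number here means a weaker inhibitor, a lower number a stronger inhibitor), compound 1 gives 870 nM and compound 2 gives 750 nM. Compound 2 stands at one of two numbers that the data set apart only by a 1.2-fold lower number from compound 1 to compound 2 (0.06 log units; within the scatter), a gap within the scatter, so neither compound can be called the stronger on this evidence.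

Compound 3 `CCN(CC)S(=O)(=O)c1ccc(S(=O)(=O)N2CCC[C@@H](C(=O)N3CC[C@H](OC)C3)C2)cc1` differs from compound 2 at the carbonyl carbon: 3-methoxypyrrolidin-1-yl in place of (oxolan-3-yl)amino on a carbonyl carbon. Here one five-membered ring with one hetero atom gives way to another, and the single hydrogen-bond donor is lost. Within the data shown here, the only step that bears on it is the exchange at the same carbonyl carbon from compound 1 to compound 2, which stayed within the scatter. A change of similar character is therefore expected to give a step in this assay of about a 1.1-fold higher number from compound 2 to compound 3 (0.05 log units; within the scatter), not beyond the scatter in either direction.

Compound 3 is accordingly estimated at 850 nM, with a likely range from 400 nM to 1800 nM.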

Compound 3, half-maximal inhibitory concentration: 2460 nM
Compound 3: the middle estimate sits 2.9-fold (0.46 log units) below what was measured; the whole stated range lies below it.
By their numbers in this assay, from the lowest: compounds 2 and 1 (each within the scatter of the next); then compound 3.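

In this assay the carbonyl carbon proves sensitive to what it carries: 3-methoxypyrrolidin-1-yl in place of (oxolan-3-yl)amino brings a 3.3-fold higher number from compound 2 to compound 3 (0.52 log units; beyond the scatter) and in place of 4-hydroxypiperidin-1-yl brings a 2.8-fold higher number from compound 1 to compound 3 (0.45 log units; beyond the scatter), whereas the exchange between the two earlier groups had stayed within the scatter. The entering group has 0 hydrogen-bond donors against 1 for (oxolan-3-yl)amino and 7 heavy atoms against 6, so this single swap alters both counts at once. Nothing at hand accounts for the rise in the number.

The compounds shown therefore leave open whether the step follows the loss of the amide hydrogen or the presence of the methoxy group. Plain pyrrolidin-1-yl or methyl(oxolan-3-yl)amino on the same carbonyl carbon would pull these two apart.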